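Swapping the aryl group on the ketone arm

The source may report more compounds than this note shows. Statements on the series, on what has been measured and on what is new or still open speak of the compounds shown alone.

Compound 1, `CC(=O)/C=C1\C[C@H]2SC(C)(C)[C@H](C(=O)OC(c3ccccc3)c3ccccc3)N2C1=O`: > 100000 nM
Compound 2, `CC1(C)S[C@@H]2/C(=C\C(=O)c3ccc([N+](=O)[O-])cc3)C(=O)N2[C@H]1C(=O)OC(c1ccccc1)c1ccccc1`: 44100 nM

Both compounds were tested in a functional assay on OE19 cells (Homo sapiens) for cytotoxicity, read by MTT assay, with a stated time of 48 h; on this read-out lower numbers stand for stronger inhibition and higher numbers for weaker inhibition. In that assay compound 1 gives > 100000 nM, and this is a limit of the assay rather than a number. Compound 1 therefore sits at the limit of > 100000 nM in this assay, at which 1 of the 2 values shown sits. Within the data shown here, compound 2 gives 44100 nM in this assay, and this is the only true number among the two values shown.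

The next compound, compound 3, `CC1(C)S[C@@H]2/C(=C\C(=O)c3cc(F)cc(F)c3)C(=O)N2[C@H]1C(=O)OC(c1ccccc1)c1ccccc1`, differs from compound 2 in one place: 3,5-difluorophenyl in place of 4-nitrophenyl on a carbonyl carbon. Among the measured compounds shown here, no pair of measured compounds shows the effect of such a change, so nothing here tells how large a step it should produce or in which direction. Without such a measured step, the plain expectation for this assay is a change that stays within the usual scatter of repeated measurements. Compound 3 is therefore estimated at 60000 nM, with a range from 15000 nM to 200000 nM. This estimate means an expected step of a 1.4-fold higher number from compound 2 to compound 3 (0.13 log units; within the scatter), and the range is wide because the change rests on no measured comparison.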

Compound 3, half-maximal inhibitory concentration: 17600 nM
For compound 3 the middle estimate is 3.4-fold (0.53 log units) above the measured one; the measured number falls inside the stated range.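

In this assay, the aryl group on the ketone arm now has its first measured comparison: putting 3,5-difluorophenyl in place of 4-nitrophenyl on a carbonyl carbon gives a 2.5-fold lower number from compound 2 to compound 3 (0.40 log units; beyond the scatter). This position is therefore not indifferent to what it carries, since exchanging one substituted aromatic ring for another, with the rest of the molecule unchanged, moves the read-out towards stronger inhibition, although the step is modest and compound 3 still gives 17600 nM. Nothing in the data shown accounts for the direction or size of this step.

With only these two aryl groups compared, the loss of the nitro group cannot be separated from the gain of the two fluorines, so the compounds shown do not tell how plain phenyl or a ring with a single fluorine would behave at this position. They also leave open what a pyridine ring would do here, and whether a free carboxylic acid in place of the diphenylmethyl ester would keep the same trend.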